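A Methylsulfonyl Group Replaces Fluoro on Compound 1

The source may report more compounds than this note shows. Statements on the series, on what has been measured and on what is new or still open speak of the compounds shown alone.

Compound 1 `Cc1noc(-c2nc(C)c3c(c2N)C(=O)N(Cc2ccc(F)cc2)C3=O)n1` is the starting point. In a physicochemical assay for solubility, using the shake flask method, in simulated intestinal fluid, measured as kinetic solubility, with a stated time of 2 h, at 25 degrees C, at pH 6.5 (a higher number here means a more soluble compound, a lower number a less soluble compound), compound 1 gives < 5000 nM, which is a limit of the assay and not a number. Compound 2 `Cc1noc(-c2nc(C)c3c(c2N)C(=O)N(Cc2ccc(Oc4ccc(F)cc4)cc2)C3=O)n1` gives 23800 nM in this assay. Compound 3 `Cc1noc(-c2nc(C)c3c(c2N)C(=O)N(Cc2ccccc2Cl)C3=O)n1` gives < 5000 nM in this assay, again a limit and not a number. Two of the three values sit at the limit of < 5000 nM in this assay, at which 2 of the 3 values shown sit, so compound 1 stands only at a boundary, not at a known point. Two measured steps begin at compound 1: an at least 4.7-fold higher number from compound 1 to compound 2 (0.67 log units; beyond the scatter), and a step that the two limits leave unreadable from compound 1 to compound 3. Compound 4 `Cc1noc(-c2nc(C)c3c(c2N)C(=O)N(Cc2ccc(S(C)(=O)=O)cc2)C3=O)n1` differs from compound 1 in one place: methylsulfonyl in place of fluoro on an aromatic carbon. Within the data shown here, no measured step introduces a methylsulfonyl group, so the only readable step, an at least 4.7-fold higher number from compound 1 to compound 2 (0.67 log units; beyond the scatter), is the nearest comparison, and it shows that replacing the fluoro group with a larger substituent moved the number up out of the limit. On that basis a step of an at least 2.4-fold higher number from compound 1 to compound 4 (0.38 log units; beyond the scatter) is expected in this assay, upward but of uncertain size, with a real chance that the result again comes back only as a limit. Compound 4 is therefore estimated to give about 12000 nM in this assay, within a range from 3000 nM to 50000 nM.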

Compound 4, solubility: < 5000 nM
Compound 4: no number, only a limit (the forecaster's own chance of this, stated with the estimate: 35%); middle value at least 2.4-fold (0.38 log units) away from the limit.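

Replacing fluoro with methylsulfonyl on this aromatic carbon, para to a large group, does not bring a readable number: in this assay compound 4 gives < 5000 nM, which is a limit of the assay and not a number. Exchanging fluoro for a group of more heavy atoms therefore does not by itself lead to a readable value at this position, and among the groups shown there only 4-fluorophenoxy does so, with an at least 4.7-fold lower number from compound 2 to compound 4 (0.67 log units; beyond the scatter). The steps to compound 4 from compound 1 and from compound 3 join two limits and cannot be read: the limit of < 5000 nM in this assay, at which 3 of the 4 values shown sit.

On these data alone, how far compound 1, compound 3 and compound 4 lie under that limit remains open, so fluoro and methylsulfonyl cannot be placed in any order at this position. Also open, as far as these compounds go, is whether the readable value of compound 2 depends on its ether oxygen, its second aromatic ring or the fluoro group on that ring, and whether an amine, a carboxylic acid or an unsubstituted phenoxy group on the same carbon would also give a readable value.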